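This account rests on a few compounds, and the source may have more. Where it says the series, first, only, none or still open, it means among the compounds named here.

Measured compounds:
Compound 1 `CCS(=O)(=O)CCC12CCC(c3nnc(-c4ccccc4C)n3C)(CC1)CC2`: 86%
Compound 2 `Cn1c(-c2ccccc2C(F)(F)F)nnc1C12CCC(CCCC(C)(F)F)(CC1)CC2`: 99%

In a functional assay on the whole organism (strain ICR) for inhibition, with Mus musculus as the target, with a stated time of 4 h, at a dose of 10 mg/kg by the oral route (a higher number here means more inhibition at the dose given (going by the name of the read-out), a lower number less inhibition), compound 2 gives 99%, the higher of the two numbers recorded. Compound 1 gives 86%, a number lower by a gap beyond the usual scatter. Compound 3 `CC(F)CCCC12CCC(c3nnc(-c4ccccc4C(F)(F)F)n3C)(CC1)CC2` differs from compound 2 in a single place: hydrogen in place of fluoro on a saturated chain carbon bound to a fluorine atom and two saturated chain carbons. Among the measured compounds shown here, no pair of measured compounds shows a change of this kind, so the step expected in this assay is a number 6 percentage points lower from compound 2 to compound 3 (within the scatter), a small loss that need not exceed the scatter. Compound 3 is therefore estimated to give 93%, within the range 80% to 100%.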

Compound 3, a percentage reported as inhibition, in the whole organism at one dose (the size of the read-out at that dose, not a potency): 96%
For compound 3 the middle estimate is 3 percentage points below the measured one; measured number inside the range.
By their numbers in this assay, from the lowest: compounds 1, 3 and 2 (each within the scatter of the next, the first and the last beyond it).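

In this assay the change reads as a number 3 percentage points lower from compound 2 to compound 3 (within the scatter) on the saturated chain carbon bound to a fluorine atom and two saturated chain carbons, so one fluoro at this carbon can give way to hydrogen without a step beyond the scatter. Among the compounds shown here, this is the first reading at this position, as compound 1 differs from compound 2 in more than one place. Nothing given here bears on why the step is this small. Still open, as far as these compounds go, is what replacing the remaining fluoro with hydrogen, or with a hydroxyl or a nitrile, would give at this carbon. Also open, from the compounds shown here alone, is how a longer chain would read in this assay when it carries the same 2-fluoropropyl end.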